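The compounds below may be only part of what the source reports. "The series", "measured", "known", "first", "only" and "open" are said of these compounds alone.

Measured so far:
compound 1 `O=C(Nc1ccc([N+](=O)[O-])cc1)c1c(O)c2cccnc2n(-c2ccccc2)c1=O` — -25.8%
compound 2 `O=C(Nc1cccc(Cl)c1)c1c(O)c2cccnc2n(-c2ccccc2)c1=O` — 13.4%

In a functional assay on the whole organism for inhibition, with Rattus norvegicus as the target, read by cytopathic effect and paw edema, at a dose of 100 mg/kg by the oral route (a higher number here means more inhibition at the dose given (going by the name of the read-out), a lower number less inhibition), compound 1 gives -25.8%, and compound 2 gives 13.4%. Compound 2 thus stands highest of the two numbers, the step of a number 39.2 percentage points higher from compound 1 to compound 2 (beyond the scatter) being beyond the scatter. Compound 3 `O=C(Nc1cnccn1)c1c(O)c2cccnc2n(-c2ccccc2)c1=O` is next, and it differs from compound 2 in one place: pyrazin-2-yl in place of 3-chlorophenyl on an amide-type nitrogen. Going by the values given here, no measured step bears directly on this change; the only step available, a number 39.2 percentage points higher from compound 1 to compound 2 (beyond the scatter), swaps one group for another on the same amide-type nitrogen and shows that the group there can move this assay by a large amount in either sense. Among the compounds with values here, with no step from an aryl group to a heteroaryl group on record, the direction of the change cannot be fixed, and the step that is expected is a number 8.4 percentage points lower from compound 2 to compound 3 (within the scatter), a step of no confident size beyond the scatter. Compound 3 is therefore estimated at 5%, within -25% to 35%.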

Compound 3, a percentage reported as inhibition, in the whole organism at one dose (the size of the read-out at that dose, not a potency): 21.2%
Compound 3: middle estimate off by 16.2 percentage points, on the low side; the measured number falls inside the stated range.
By their numbers in this assay, from the lowest: compound 1; then compounds 2 and 3 (each within the scatter of the next).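

In this assay the step of a number 7.8 percentage points higher from compound 2 to compound 3 (within the scatter) shows that this amide-type nitrogen can carry a six-membered aromatic ring with hetero atoms in place of the 3-chlorophenyl ring with no difference that stands clear of the scatter. The step of a number 47 percentage points higher from compound 1 to compound 3 (beyond the scatter) then sets the pyrazin-2-yl group well apart from the 4-nitrophenyl group, so compound 1 now stands apart from both of the other compounds, and not from compound 2 alone. Nothing shown here explains these numbers.

The compounds shown leave open whether the low number of compound 1 goes with the nitro group or with its place on the ring, a question that a 4-chlorophenyl or a 3-nitrophenyl group would address. They also leave open how a pyridin-2-yl group or a benzyl group on the same nitrogen would read.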